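Fluoro to cyano on the pyridine of an alkyne series

This account rests on a few compounds, and the source may have more. Where it says the series, first, only, none or still open, it means among the compounds named here.

Measured compounds:
compound 1, `COc1cc(C#N)cc(C#Cc2cccc(C)n2)c1`, 1.29 nM
compound 2, `N#Cc1cc(F)cc(C#Cc2cccc(F)n2)c1`, 41 nM

The two compounds were characterised in an assay on membranes from brain (strain Sprague-Dawley) for displacement of a labelled ligand from metabotropic glutamate receptor 5 (Rattus norvegicus), read by scintillation counting, with a stated time of 60 min; a lower number here means a stronger inhibitor, a higher number a weaker inhibitor. Compound 1 gave 1.29 nM, while compound 2 gave 41 nM, the higher of the two numbers and therefore the weaker inhibitor of this pair; the gap between them lies beyond the usual scatter of this assay, though the two compounds differ in more than one place, so no single change can be credited with it.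

Compound 3, `N#Cc1cc(F)cc(C#Cc2cccc(C#N)n2)c1`, has not yet been tested. It differs from compound 2 in one place: cyano in place of fluoro on an aromatic carbon. In the absence of any measured pair that isolates this exchange, the expectation can rest only on the values of compound 1 and compound 2 and on the nature of the change.

Compound 3 is expected to sit somewhat below compound 2 in this assay, with an estimated step of a 2.1-fold lower number from compound 2 to compound 3 (0.31 log units; beyond the scatter). The estimated value for compound 3 is 20 nM, within a range of 5 nM to 80 nM.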

Compound 3, inhibition constant: 2.7 nM
Beside the measured number, compound 3's estimate is 7.4-fold (0.87 log units) above it; measured number outside the range, below it.
By their numbers in this assay, from the lowest: compound 1; then compound 3; then compound 2.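

In this assay, putting cyano in place of fluoro on an aromatic carbon, next to the ring nitrogen, gives a 15-fold lower number from compound 2 to compound 3 (1.18 log units; beyond the scatter), a large step beyond the usual scatter. For the compounds shown here, this is the first comparison that isolates a single change, and it shows that this position is sensitive to its substituent: with the rest of compound 2 left as it is, this one exchange accounts for the whole step. No measurement in hand explains the size of this step or connects it to any property of either group.

Methyl sits at this position in compound 1, but that compound also differs in another place, so it cannot show how methyl ranks against fluoro or cyano here, and whether an amine, a carboxylic acid or a longer chain at this position would be tolerated remains open. It is also unknown whether the same exchange would give a step of similar size on the core of compound 1, where methoxy stands in place of fluoro on the other ring.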